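Ethyl to vinyl in a flat series

The source may report more compounds than this note shows. Statements on the series, on what has been measured and on what is new or still open speak of the compounds shown alone.

Compound 1 `O=C1Nc2ccccc2/C1=C\C(=O)c1cccc(Cl)c1`: 9800 nM
Compound 2 `CCC(=O)Nc1cccc(C(=O)/C=C2/C(=O)Nc3ccccc32)c1`: 10300 nM
Compound 3 `O=C1Nc2ccccc2/C1=C\C(=O)c1ccccc1F`: 8500 nM

These three values all come from a functional assay on NCI-H460 cells (Homo sapiens) for inhibition, read by MTT assay, with a stated time of 72 h (a lower number here means a stronger inhibitor, a higher number a weaker inhibitor), and give little to separate the compounds. Compound 2 stands level with the other two, and its gaps to both lie within the scatter.

The next compound, compound 4 `C=CC(=O)Nc1cccc(C(=O)/C=C2/C(=O)Nc3ccccc32)c1`, differs from compound 2 in one place. The change is vinyl in place of ethyl on a carbonyl carbon and in plain terms it puts vinyl in place of ethyl on a carbonyl carbon, turning propanoylamino into (vinylcarbonyl)amino.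

Among the compounds with values here, only one measured step touches this part of the molecule: a 1.1-fold higher number from compound 1 to compound 2 (0.02 log units; within the scatter) when propanoylamino replaced chloro. That step is a swap of a whole group, and it left the number within the scatter. Within the data shown here, no measured compound carries vinyl, so the data say nothing direct about this change. The expectation in this assay is therefore no step beyond the scatter, with a slight lean towards a lower number that rests on judgement alone. The expected step is a 1.5-fold lower number from compound 2 to compound 4 (0.17 log units; within the scatter) and it stays modest. As far as these compounds go, compound 4 is estimated at 7000 nM with an expected range from 2000 nM to 14000 nM and this range is kept wide since vinyl is untested here.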

Compound 4, half-maximal inhibitory concentration: 3200 nM
Beside the measured number, compound 4's estimate is 2.2-fold (0.34 log units) above it, and the stated range covers the measured number.
By their numbers in this assay, from the lowest: compound 4; then compounds 3, 1 and 2 (each within the scatter of the next).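

In this assay, within the data shown here, vinyl in place of ethyl on a carbonyl carbon gives a 3.2-fold lower number from compound 2 to compound 4 (0.51 log units; beyond the scatter) and is the first single change in this set to pass beyond the scatter, although the number of heavy atoms stays the same and the counted difference is one double bond outside aromatic rings. The earlier swap gave only a 1.1-fold higher number from compound 1 to compound 2 (0.02 log units; within the scatter), so the amide-type group alone moved nothing, while (vinylcarbonyl)amino in place of chloro gives a 3.1-fold lower number from compound 1 to compound 4 (0.49 log units; beyond the scatter), which shows that at this position the small group on the carbonyl carbon can matter more than replacing chloro with propanoylamino did. Nothing available here explains why this small change shifts the number.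

The compounds shown leave open whether the lower number belongs to the vinyl group specifically or would also appear with other groups on that carbonyl carbon, such as a longer chain with a double bond, or a vinyl group bearing an amine. They also leave open whether the same step would hold in any other cell line.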